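This account rests on a few compounds, and the source may have more. Where it says the series, first, only, none or still open, it means among the compounds named here.

Measured in a functional assay on MCF7 cells (Homo sapiens) for antiproliferative activity, read by MTT assay, with a stated time of 48 h; on this read-out higher numbers stand for weaker inhibition and lower numbers for stronger inhibition:
- Compound 1 `CCCCCCCn1cc(COC[C@@H]2OC[C@H](N)[C@@H]2O)nn1`: > 128000 nM, a limit of the assay
- Compound 2 `CCCCCCCCn1cc(COC[C@@H]2OC[C@H](N)[C@@H]2O)nn1`: 28100 nM
- Compound 3 `CCCCCCCCn1cc(COC[C@@H]2OC[C@H](N)[C@H]2O)nn1`: > 128000 nM, a limit of the assay

Compound 3 sits at the limit of > 128000 nM in this assay, at which 2 of the 3 values shown sit, so only compound 2 has a true number in this assay. Compound 4 `CCCCCCCCCCCCCCn1cc(COC[C@@H]2OC[C@H](N)[C@H]2O)nn1` keeps the configuration of compound 3 and carries the change (hexyl in place of hydrogen on a saturated chain carbon, eight bonds along the chain from an aromatic nitrogen), with hexyl in place of hydrogen on the chain.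

Among the compounds with values here, two measured steps bear on this change. The closer in kind is an at least 4.5-fold lower number from compound 1 to compound 2 (0.65 log units; beyond the scatter), where methyl replaces hydrogen on the chain and the number falls. Within the data shown here, it is a much smaller change than the one in compound 4, so it points the way but does not set a size. The other is an at least 4.5-fold higher number from compound 2 to compound 3 (0.65 log units; beyond the scatter), which goes with configuration alone because of the fact that compounds 2 and 3 differ only in the configuration as drawn. It shows that the configuration of compound 3 carries a cost, and compound 4 retains that configuration.

Both steps start from or end at a limit, so their sizes are bounds. A lower number is expected for the hexyl change, at least modest in size, with a real chance that the result stays at the limit. The expected change is an at least 7.1-fold lower number from compound 3 to compound 4 (0.85 log units; beyond the scatter). For compound 4 the estimated value is 18000 nM, with an expected range from 5000 nM to 70000 nM.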

Compound 4, half-maximal inhibitory concentration: 2450 nM
For compound 4 the middle estimate is 7.3-fold (0.87 log units) above the measured one; measured number below the stated range.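

In this assay compound 3 gives > 128000 nM, which is a limit of the assay and not a number, so the step that starts from it is a bound. The hexyl change on a saturated chain carbon, eight bonds along the chain from an aromatic nitrogen, gives an at least 52-fold lower number from compound 3 to compound 4 (1.71 log units; beyond the scatter), a large step, and it shows that lengthening the chain lowers the number in this configuration too, whereas the earlier methyl step belonged to the other configuration. With the configuration of compound 3 kept, compound 4 gives a true number of 2450 nM, so this configuration does not by itself rule out a measured value.

Still open, going by these compounds, is whether a longer chain than that of compound 4 would lower the number further, and whether an amine or a carboxylic acid on the chain would keep any of this step. Also open, on these data alone, is how far the chain of compound 4 would read with the configuration of compound 2, so the cost of configuration at this chain length has no size here.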